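The compounds below may be only part of what the source reports. "The series", "measured", "known", "first", "only" and "open" are said of these compounds alone.

Compounds measured so far in a functional assay on NCI-H460 cells (Homo sapiens) for cytotoxicity, read by MTT assay, with a stated time of 72 h; on this read-out lower numbers stand for stronger inhibition and higher numbers for weaker inhibition:

compound 1, `CN(C)CCn1cnnc1-c1cc(Oc2ccc(NC(=O)N/N=C/c3ccc(F)cc3Cl)cc2F)ccn1`, gives 720 nM
compound 2, `CN(C)CCn1cnnc1-c1cc(Oc2ccc(NC(=O)N/N=C/c3ccc(Cl)cc3)cc2F)ccn1`, gives 320 nM
compound 3, `CN(C)CCn1cnnc1-c1cc(Oc2ccc(NC(=O)N/N=C/c3ccc(O)c(F)c3)cc2F)ccn1`, gives 2620 nM

Compound 1 stands second highest of the three numbers in this assay. Its nearest neighbour is compound 2, reached by a 2.3-fold lower number from compound 1 to compound 2 (0.35 log units; beyond the scatter); its furthest is compound 3, reached by a 3.6-fold higher number from compound 1 to compound 3 (0.56 log units; beyond the scatter). Compound 4, `CN(C)CCn1cnnc1-c1cc(Oc2ccc(NC(=O)N/N=C/c3ccc(O)c(O)c3)cc2F)ccn1`, has not yet been measured. It differs from compound 1 in one place: 3,4-dihydroxyphenyl in place of 2-chloro-4-fluorophenyl on a carbon with a double bond to nitrogen.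

For the measured compounds named here, two measured steps bear on this change, both leading to the 3-fluoro-4-hydroxyphenyl compound: a 3.6-fold higher number from compound 1 to compound 3 (0.56 log units; beyond the scatter) and an 8.2-fold higher number from compound 2 to compound 3 (0.91 log units; beyond the scatter). Compound 4 carries a 3,4-dihydroxyphenyl group, which shares the 4-hydroxy with compound 3 and lacks any halogen on that ring. The step from compound 1 to compound 4 is therefore expected to run in the same direction as the step to compound 3, towards a higher number, and is estimated at a 4.9-fold higher number from compound 1 to compound 4 (0.69 log units; beyond the scatter). Compound 4 is thus expected to give about 3500 nM in this assay, within a range from 1200 nM to 10000 nM.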

Compound 4, half-maximal inhibitory concentration: 1930 nM
Compound 4: the middle estimate sits 1.8-fold (0.26 log units) above what was measured; the measured number falls inside the stated range.
By their numbers in this assay, from the lowest: compound 2; then compound 1; then compounds 4 and 3 (each within the scatter of the next).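

In this assay, replacing the fluoro of compound 3 with a hydroxy on an aromatic carbon does not separate the two compounds (a 1.4-fold lower number from compound 3 to compound 4 (0.13 log units; within the scatter)), so the higher number seen with the 3-fluoro-4-hydroxyphenyl group does not depend on that fluoro. The 3,4-dihydroxyphenyl group also stands clearly above both halogen-only groups (a 2.7-fold higher number from compound 1 to compound 4 (0.43 log units; beyond the scatter); a 6.0-fold higher number from compound 2 to compound 4 (0.78 log units; beyond the scatter)), and among the four compounds, none goes against this split between hydroxy-bearing and halogen-only rings. No measurement shown accounts for this split.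

The compounds shown leave open whether a plain 4-hydroxyphenyl group would fall with compound 3 and compound 4. They also leave open whether a methoxy or an amine in place of the hydroxy would give a number nearer that of compound 2.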